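Chalcone dithiocarbamate ethers: one more chain carbon from compound 1

A few compounds are considered here, and "the series" means these few. Any claim that something is new, unique, unknown or untested is made for them only; others in the source may bear on it.

Measured so far in a functional assay on ECa-109 cells for inhibition, with ECa-109 cell line (Homo sapiens) as the target, read by MTT assay, with a stated time of 72 h; a higher number here means a weaker inhibitor, a lower number a stronger inhibitor:
compound 1 `COc1cc(/C=C/C(=O)c2ccc(OCCSC(=S)N3CCCC3)cc2)cc(OC)c1OC` gives 10700 nM
compound 2 `COc1ccc(/C=C/C(=O)c2ccc(OCCCSC(=S)N3CCN(C)CC3)cc2)cc1` gives > 100000 nM, which is a limit of the assay and not a number

Within the data shown here, compound 1 holds the only number in this assay. Compound 2 sits at the limit (the limit of > 100000 nM in this assay, at which 1 of the 2 values shown sits). Compound 3 `COc1cc(/C=C/C(=O)c2ccc(OCCCSC(=S)N3CCCC3)cc2)cc(OC)c1OC` differs from compound 1 by a group of 9 heavy atoms (6 carbon, 1 nitrogen, 2 sulfur; one five-membered non-aromatic ring with 1 hetero atom) in place of a group of 8 heavy atoms (5 carbon, 1 nitrogen, 2 sulfur; one five-membered non-aromatic ring with 1 hetero atom), on a saturated chain carbon, two bonds along the chain from an oxygen on an aromatic ring. Among the measured compounds shown here, no measured pair shares this change, and compound 2 differs from compound 1 in more than one place, so its limit says nothing about this step on its own. So small a change is expected to stay within the scatter, in no set direction, and the step is estimated as a 1.1-fold lower number from compound 1 to compound 3 (0.03 log units; within the scatter). Compound 3 is therefore expected near 10000 nM, with a range from 4000 nM to 30000 nM.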

Compound 3, half-maximal inhibitory concentration: 11100 nM
Compound 3: middle estimate off by 1.1-fold (0.05 log units), on the low side; the measured number falls inside the stated range.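

In this assay, among these compounds, the first readable step at this position gives a 1.0-fold higher number from compound 1 to compound 3 (0.02 log units; within the scatter), so with the shared core and the five-membered ring held, the change on a saturated chain carbon, two bonds along the chain from an oxygen on an aromatic ring, leaves the read-out within the scatter. Nothing in hand bears on this step. On these data alone, whether a longer chain, or diethylamine in place of the five-membered ring, would hold this level stays open. Compound 2 gives > 100000 nM, a limit of the assay, and differs from compound 3 in more than one place, so it settles neither question.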